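Amide series: cytotoxicity on THP-1 cells, working notes

The source may report more compounds than this note shows. Statements on the series, on what has been measured and on what is new or still open speak of the compounds shown alone.

Measured so far:
compound 1, `COc1ccc(-c2cnc(NC(=O)c3ccccc3O)n2C)cc1`: in a toxicity assay on THP-1 cells (Homo sapiens) for inhibition (on this read-out higher numbers stand for lower toxicity in this test and lower numbers for higher toxicity in this test), compound 1 gives > 100000 nM, a limit of the assay and not a number.
compound 2, `COc1ccc(-c2cnc(NC(=O)c3cccc(C#N)c3)n2C)cc1`: in this assay compound 2 gives > 100000 nM, again a limit of the assay.

Both values sit at the limit of > 100000 nM in this assay, at which 2 of the 2 values shown sit. Among the compounds with values here, the only measured step, a step that the two limits leave unreadable from compound 1 to compound 2, is therefore unreadable in size and direction. Compound 2 stands at the limit, with no number of its own.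

Compound 3, `COc1ccc(-c2cnc(NC(=O)c3cccc(C)c3)n2C)cc1`, differs from compound 2 by methyl in place of cyano on an aromatic carbon. Within the data shown here, no measured step covers this exchange, and the one step available, a step that the two limits leave unreadable from compound 1 to compound 2, gives no size to carry over. The expectation for compound 3 is that it stays at the limit, with a number no higher from compound 2 to compound 3 (the limit leaves the size open) expected to be no step beyond the scatter. Compound 3 is thus estimated at 100000 nM, within a range of 50000 nM to 200000 nM, most likely reported again only as a limit.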

Compound 3, half-maximal cytotoxic concentration: > 100000 nM
Compound 3: a limit, no number (the forecaster's own chance of this, stated with the estimate: 80%); the middle value sits exactly at the limit.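

No step among compound 1, compound 2 and compound 3 can be read in this assay, as each result is a limit of the assay and not a number: the limit of > 100000 nM in this assay, at which 3 of the 3 values shown sit.

The compounds shown leave open how the 2-hydroxyphenyl, 3-cyanophenyl and 3-methylphenyl amides compare in this assay.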